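A few compounds are considered here, and "the series" means these few. Any claim that something is new, unique, unknown or untested is made for them only; others in the source may bear on it.

Measured compounds:
Compound 1 `COc1cc2ncnc(Nc3ccc(F)c(Cl)c3)c2cc1OCCCCC(=O)Nc1ccc(S(N)(=O)=O)cc1` gives 15500 nM in a functional assay on A549 cells (Homo sapiens) for antiproliferative activity, read by MTT assay, with a stated time of 72 h; a lower number here means a stronger inhibitor, a higher number a weaker inhibitor.
Compound 2 `COc1cc2ncnc(Nc3ccc(F)cc3)c2cc1OCCCCC(=O)Nc1ccc(S(N)(=O)=O)cc1` reaches only a limit of the assay, > 40000 nM, in this assay.
Compound 3 `COc1cc2ncnc(Nc3ccc(Br)cc3)c2cc1OCCCCC(=O)Nc1ccc(S(N)(=O)=O)cc1` likewise reaches only a limit, > 40000 nM, in this assay.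

Going by the values given here, compound 1 is thus the only one with a number; the other two values are limits (the limit of > 40000 nM in this assay, at which 2 of the 3 values shown sit). Compound 4 `COc1cc2ncnc(Nc3ccc(OC(F)(F)F)cc3)c2cc1OCCCCC(=O)Nc1ccc(S(N)(=O)=O)cc1` differs from compound 1 by 4-(trifluoromethoxy)phenyl in place of 3-chloro-4-fluorophenyl on a nitrogen on an aromatic ring. Among the compounds with values here, two measured steps bear on this change. The step of an at least 2.5-fold higher number from compound 1 to compound 2 (0.41 log units; beyond the scatter) and the step of an at least 2.5-fold higher number from compound 1 to compound 3 (0.41 log units; beyond the scatter) both leave the 3-chloro-4-fluorophenyl for a different aromatic ring on the same nitrogen, and both end at the limit. A comparable weakening is therefore expected for compound 4, given that compound 3 showed > 40000 nM. Compound 4 is estimated at 40000 nM, with a range of 15000 nM to 100000 nM, a step of a 2.6-fold higher number from compound 1 to compound 4 (0.41 log units; beyond the scatter).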

Compound 4, half-maximal inhibitory concentration: > 40000 nM
Compound 4: a limit, no number; the forecaster's own chance of this, stated with the estimate: 65%; the middle value lies on the limit itself.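

In this assay compound 4 reaches only a limit, not a number. Exchanging 3-chloro-4-fluorophenyl for 4-(trifluoromethoxy)phenyl on this nitrogen gives an at least 2.5-fold higher number from compound 1 to compound 4 (0.41 log units; beyond the scatter), which extends the loss to a third replacement ring, while the steps among compound 2, compound 3 and compound 4 cannot be read. Only compound 1 keeps a number at this position, and the limit now holds most of the series: the limit of > 40000 nM in this assay, at which 3 of the 4 values shown sit.

As far as these compounds go, it remains open how far compound 2, compound 3 and compound 4 lie from one another. From the compounds shown here alone, it also remains open whether a 3-chlorophenyl or a 3-aminophenyl on this nitrogen would return a number.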